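The source may report more compounds than this note shows. Statements on the series, on what has been measured and on what is new or still open speak of the compounds shown alone.

- compound 1 `CC(=O)/C(=C\c1ccccc1)Oc1ccccc1OCCCNC(C)(C)C` with 1.5 mg/kg
- compound 2 `CC(=O)/C(=C\c1ccccc1)Oc1ccccc1OCC(O)CN1CCN(C)CC1` with 7.5 mg/kg

In a functional assay on the whole organism (heart) with Rattus norvegicus as the target (on this read-out higher numbers stand for an effect only at larger amounts of compound and lower numbers for an effect already at smaller amounts), compound 2 has the higher number of the two, at 7.5 mg/kg. Compound 3 `CC(=O)/C(=C\c1ccccc1)Oc1ccccc1OCCCN(C)C` carries 2-(dimethylamino)ethyl in place of 1-hydroxy-2-(4-methylpiperazin-1-yl)ethyl (2-(dimethylamino)ethyl in place of 1-hydroxy-2-(4-methylpiperazin-1-yl)ethyl on a saturated chain carbon bound to an oxygen on an aromatic ring). Among the measured compounds shown here, the one measured step bearing on this is modest and beyond the scatter (a 5.0-fold higher number from compound 1 to compound 2 (0.70 log units; beyond the scatter)). It introduced the group that now leaves, and the entering group, like the 2-((tert-butyl)amino)ethyl of compound 1, has no ring. A partial return towards lower numbers is therefore expected (a 2.5-fold lower number from compound 2 to compound 3 (0.40 log units; beyond the scatter)). Compound 3 is estimated at 3 mg/kg (expected range 1.2 mg/kg to 7.5 mg/kg).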

Compound 3, dose for half-maximal effect: 0.37 mg/kg
For compound 3 the middle estimate is 8.1-fold (0.91 log units) above the measured one; the whole stated range lies above it.
By their numbers in this assay, from the lowest: compound 3; then compound 1; then compound 2.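

In this assay, the step of a 20-fold lower number from compound 2 to compound 3 (1.31 log units; beyond the scatter) is large, and 2-(dimethylamino)ethyl gives the lowest number of the three compounds at this position. Among the compounds shown here, the step of a 4.1-fold lower number from compound 1 to compound 3 (0.61 log units; beyond the scatter) shows that the number also moves beyond the scatter between two amine ends without a ring, so the ring is not the only change that counts here. No evidence is available to explain either step. From the compounds shown here alone, because compound 2 differs from compound 3 in both the hydroxy group and the ring, their separate shares remain open. Going by these compounds, whether a primary amine, a pyrrolidine or a longer chain would give a still lower number also remains open.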